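A few compounds are considered here, and "the series" means these few. Any claim that something is new, unique, unknown or untested is made for them only; others in the source may bear on it.

Measured so far in a functional assay on the whole organism for inhibition, with Rattus norvegicus as the target, at a dose of 0.3 mg/kg; on this read-out higher numbers stand for more inhibition at the one dose given (going by the name of the read-out) and lower numbers for less inhibition:

- compound 1 `CCCCn1nc(C)c(C(=O)O)c1Cc1ccc(-c2ccccc2-c2nn[nH]n2)cc1`: 62.6%
- compound 2 `CCCCn1nc(CC)c(C(=O)O)c1Cc1ccc(-c2ccccc2-c2nn[nH]n2)cc1`: 65.2%

On these two numbers compound 2 sits alongside compound 1, the two values lying within the usual scatter of each other, so neither can be called the stronger. Compound 3 `CCCCn1nc(C(C)C)c(C(=O)O)c1Cc1ccc(-c2ccccc2-c2nn[nH]n2)cc1` differs from compound 2 in one place: methyl in place of hydrogen on a saturated chain carbon bound to an aromatic carbon and a saturated chain carbon. Among the measured compounds shown here, the one measured step that bears on this change is the step that moved the same chain one carbon longer, a number 2.6 percentage points higher from compound 1 to compound 2 (within the scatter), which stayed within the scatter. Extending that chain once more is therefore expected to leave this assay essentially unchanged, with no step beyond the scatter in either direction; the expected step is a number 0.2 percentage points lower from compound 2 to compound 3 (within the scatter). For compound 3 the estimate in this assay is 65%, with a likely range from 52% to 77%. For the measured compounds named here, this rests on only two measured compounds, so the expectation is a loose one.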

Compound 3, a percentage reported as inhibition, in the whole organism at one dose (the size of the read-out at that dose, not a potency): 42.7%
The estimate for compound 3 lay 22.3 percentage points above the measured number; the whole stated range lies above it.
By their numbers in this assay, from the lowest: compound 3; then compounds 1 and 2 (each within the scatter of the next).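

In this assay the swap of ethyl for isopropyl on this aromatic carbon is not a neutral change (a number 22.5 percentage points lower from compound 2 to compound 3 (beyond the scatter)), and isopropyl also stands apart from methyl at the same place (a number 19.9 percentage points lower from compound 1 to compound 3 (beyond the scatter)). Methyl and ethyl could not be told apart here (a number 2.6 percentage points higher from compound 1 to compound 2 (within the scatter)), so adding one carbon to this group does not always leave the number unchanged: a methyl on the saturated chain carbon bound to the aromatic carbon, which makes the chain branched, goes with a clear drop. Nothing available explains why the number falls. Whether the drop belongs to the branching or simply to the extra carbon stays open: a straight propyl chain on this aromatic carbon is not among the compounds shown. A cyclopropyl group at the same place is another open case.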